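From methyl to chloro in compound 4

The source may hold more compounds than are shown below. What is called first, only, known or untested is meant among the compounds shown, and "the series" means these compounds.

Measured so far in an ADME assay on microsomes from liver (Homo sapiens) for metabolic stability, with a stated time of 10 min, tested at 1 uM (on this read-out lower numbers stand for a less stable compound and higher numbers for a more stable compound), for three compounds:
compound 1 `COc1c(-c2ccc(C(F)(F)F)cc2Cl)ccc2nn([C@@H](CC(C)C)c3ccc(C(=O)NCCC(=O)O)cc3)cc12` gives 89% here
compound 2 `COc1c(-c2ccc(C(F)(F)F)cc2Cl)ccc2nn([C@H](CC(C)C)c3ccc(C(=O)NCCC(=O)O)cc3)cc12` gives 116% here
compound 3 `Cc1cc(C(F)(F)F)ccc1-c1ccc2nn([C@@H](CC(C)C)c3ccc(C(=O)NCCC(=O)O)cc3)cc2c1C` gives 110% here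

Compound 3 lies within the scatter of compound 2 and clearly above compound 1. Compound 4 `Cc1c(-c2ccc(C(F)(F)F)cc2Cl)ccc2nn([C@@H](CC(C)C)c3ccc(C(=O)NCCC(=O)O)cc3)cc12` differs from compound 3 by a single swap, (chloro in place of methyl on an aromatic carbon), with chloro in place of methyl on an aromatic carbon. Within the data shown here, no measured step covers this swap. Among the measured compounds shown here, the only step, a number 27 percentage points higher from compound 1 to compound 2 (beyond the scatter), reflects the fact that compounds 1 and 2 differ only in the configuration as drawn and so serves merely as a yardstick of size. Compound 1 also carries 2-chloro-4-(trifluoromethyl)phenyl and gives 89% on a different core, which tilts the expectation slightly downward. A change within the scatter is expected, estimated as a number 8 percentage points lower from compound 3 to compound 4 (within the scatter) in this assay overall. For compound 4 the estimated value is 102%, with an expected range of 85% to 118% in this assay overall.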

Compound 4, percent of the compound remaining: 118%
The estimate for compound 4 lay 16 percentage points below the measured number; low and high end bracket the measured number.
By their numbers in this assay, from the lowest: compound 1; then compounds 3, 2 and 4 (each within the scatter of the next).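

In this assay, the swap of 2-methyl-4-(trifluoromethyl)phenyl to 2-chloro-4-(trifluoromethyl)phenyl does not move the read-out beyond the usual scatter, with a number 8 percentage points higher from compound 3 to compound 4 (within the scatter). The larger change comes from the other site: with the chloro-bearing ring kept in place, methyl in place of methoxy on an aromatic carbon of the core gives a number 29 percentage points higher from compound 1 to compound 4 (beyond the scatter). Nothing measured here gives a reason for either step.

On these data alone, how a nitrile or an amine in place of chloro on this carbon would read stays open. So does whether methyl in place of methoxy gives a similar step in the configuration drawn for compound 2.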